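Replacing 3-bromophenyl with 4-methoxyphenyl: what to expect

The compounds below may be only part of what the source reports. "The series", "measured", "known", "first", "only" and "open" are said of these compounds alone.

Of the compounds shown here, three that share a core have been measured so far. In a functional assay on MCF7 cells (Homo sapiens) for cytotoxicity, read by MTT assay, with a stated time of 72 h (on this read-out lower numbers stand for stronger inhibition and higher numbers for weaker inhibition), compound 1 `COc1cccc(/C=C2\CCC/C(=C\c3ccc(Cl)cc3)C2=O)c1OC` gives 10300 nM, compound 2 `COc1cccc(/C=C2\CCC/C(=C\c3ccc(Cl)c(Cl)c3)C2=O)c1OC` gives 9000 nM and compound 3 `COc1ccc(/C=C2\CCC/C(=C\c3cccc(Br)c3)C2=O)cc1OC` gives 5300 nM. These three values lie within the usual scatter of one another, so compound 3 cannot be told apart from the other two.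

The next compound, compound 4 `COc1ccc(/C=C2\CCC/C(=C\c3ccc(OC)c(OC)c3)C2=O)cc1`, has not been measured. It carries 4-methoxyphenyl in place of 3-bromophenyl on a double-bonded chain carbon bound to a double-bonded ring carbon.

Among the compounds with values here, no measured pair makes this exact exchange. Within the data shown here, the only measured single change, chloro in place of hydrogen on an aromatic carbon, gave a 1.1-fold lower number from compound 1 to compound 2 (0.06 log units; within the scatter), which is within the scatter. That is thin evidence, but it offers no reason to expect a large shift or to favour a direction.

In this assay the expected change is a 1.1-fold higher number from compound 3 to compound 4 (0.05 log units; within the scatter), which would be no step beyond the scatter. For compound 4 the estimated value is 6000 nM, with an expected range from 2500 nM to 15000 nM.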

Compound 4, half-maximal inhibitory concentration: 7800 nM
Estimate against measurement, compound 4: 1.3-fold (0.11 log units) below; low and high end bracket the measured number.
By their numbers in this assay, from the lowest: compounds 3, 4, 2 and 1 (each within the scatter of the next).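

In this assay, this position accepts quite different groups: 4-methoxyphenyl in place of 3-bromophenyl on a double-bonded chain carbon bound to a double-bonded ring carbon gives a 1.5-fold higher number from compound 3 to compound 4 (0.17 log units; within the scatter). The exchange removes the bromine and brings in oxygen, with 1 hydrogen-bond acceptor where the leaving group has 0, yet the two compounds cannot be told apart on this read-out. No measurement shown explains this result, so the reason for it remains unknown.

This is a single pair, so it remains unclear whether the same holds when the rest of the molecule differs. From the compounds shown here alone, it also remains open whether an aromatic ring carrying an amine or a carboxylic acid, or a longer chain in place of methoxy, would give a step beyond the scatter.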